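This account rests on a few compounds, and the source may have more. Where it says the series, first, only, none or still open, it means among the compounds named here.

Measured compounds:
Compound 1, `COC(=O)[C@@]1(C)CCC=C2[C@@H]1CC[C@@H](C)[C@]2(C)Cc1c(C)[nH]c2c(C)cccc12`: 14000 nM
Compound 2, `COC(=O)[C@@]1(C)CCC=C2[C@@H]1CC[C@@H](C)[C@]2(C)Cc1c(C)[nH]c2c(Br)cccc12`: 22000 nM
Compound 3, `COC(=O)[C@@]1(C)CC[C@@H]2C3=C1CC[C@@H](C)[C@]3(C)Cc1c2[nH]c2c(C)cccc12`: 12000 nM

All three were tested in a functional assay on HeLa cells (Homo sapiens) for inhibition, read by sulforhodamine B assay, with a stated time of 48 h; on this read-out higher numbers stand for weaker inhibition of growth and lower numbers for stronger inhibition of growth. In this assay compound 1 gives 14000 nM, compound 2 gives 22000 nM and compound 3 gives 12000 nM. These three numbers all lie within the scatter of one another, so none of the three compounds can be called stronger or weaker than the others.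

Compound 2 differs from compound 1 in one place: bromo in place of methyl on an aromatic carbon. That change made a step of a 1.6-fold higher number from compound 1 to compound 2 (0.20 log units; within the scatter). Compound 3 is built on another core; the difference between the two cores is not broken down here.

Compound 4, `COC(=O)[C@@]1(C)CC[C@@H]2C3=C1CC[C@@H](C)[C@]3(C)Cc1c2[nH]c2c(Br)cccc12`, has not yet been measured. It differs from compound 3 by the same kind of change: bromo in place of methyl on an aromatic carbon. The place is not identical word for word: in compound 1 the ring carrying the change is part of a fused or bridged system of two rings, in compound 3 it is part of a fused or bridged system of five rings. Among the measured compounds shown here, the only guide is the earlier step.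

The step from compound 3 to compound 4 is expected to be a 1.5-fold higher number from compound 3 to compound 4 (0.18 log units; within the scatter), resting on the step of a 1.6-fold higher number from compound 1 to compound 2 (0.20 log units; within the scatter), which stayed within the scatter. Compound 4 is therefore estimated at 18000 nM in this assay, most likely between 9000 nM and 36000 nM.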

Compound 4, concentration for 50% growth inhibition: 18000 nM
For compound 4 middle estimate and measured number coincide at the digits printed; the measured number falls inside the stated range.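

In this assay the swap of bromo for methyl on an aromatic carbon gives a 1.5-fold higher number from compound 3 to compound 4 (0.18 log units; within the scatter) and so stays within the scatter, just as it did on the first core. This does not show that the swap has a real effect of any size on either core, since a step this small cannot be told apart from repeat measurements, and two cores are too few to predict what the same swap would do on a third. What the data do show is narrower: on these two cores, bromo and methyl at this place cannot be told apart in this read-out, and the size of the step carries over from one core to the other, as the two steps match when set side by side: the same change on two cores in this assay, a 1.6-fold higher number (0.20 log units; within the scatter) from compound 1 to compound 2 and a 1.5-fold higher number (0.18 log units; within the scatter) from compound 3 to compound 4, 1.0-fold (0.02 log units) apart, within the scatter of two such steps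

The compounds shown hold only bromo or methyl at this place, so they leave open whether a larger or quite different group there, such as a methoxy group, an amine or a carboxylic acid, would move the number beyond the scatter. They also all carry the same methyl ester, so what a free carboxylic acid or an amide at that spot would do on either core remains an open question.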